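Methyl to benzyl on a selenium-bearing imidoyl core

The compounds below may be only part of what the source reports. "The series", "measured", "known", "first", "only" and "open" are said of these compounds alone.

Within the data shown here, compound 1, with the structure `C[Se]/C(=N\C(=O)c1cc2ccccc2s1)NC(=O)c1cc2ccccc2s1`, is the one member of this small set for which a number, rather than a limit, is in hand. In a functional assay on K562 cells (Homo sapiens) for cytotoxicity, read by MTT assay, with a stated time of 72 h (on this read-out higher numbers stand for lower toxicity in this test and lower numbers for higher toxicity in this test), compound 1 gives 89600 nM. Its companion, compound 2, with the structure `CS/C(=N\C(=O)c1csc([N+](=O)[O-])c1)NC(=O)c1csc([N+](=O)[O-])c1`, carries a different core and a sulfur in place of the selenium. In this assay compound 2 gives > 100000 nM, which is a limit of the assay and not a number. Compound 2 therefore sits at the limit of > 100000 nM in this assay, at which 1 of the 2 values shown sits. Among the measured compounds shown here, compound 3, with the structure `O=C(/N=C(/NC(=O)c1cc2ccccc2s1)[Se]Cc1ccccc1)c1cc2ccccc2s1`, is the unmeasured partner of compound 1; the single change is phenyl in place of hydrogen on a saturated chain carbon bound to a selenium atom. For the measured compounds named here, no step between two measured compounds is available to calibrate this change, so the expectation rests on compound 1 alone. The step from compound 1 to compound 3 is estimated at a 1.5-fold lower number from compound 1 to compound 3 (0.17 log units; within the scatter) in this assay, that is, a shift not clearly beyond the scatter toward somewhat higher toxicity. Compound 3 is accordingly expected to give about 60000 nM, within a range from 15000 nM to 150000 nM.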

Compound 3, concentration lethal to 50% of the cells: 70600 nM
For compound 3 the middle estimate is 1.2-fold (0.07 log units) below the measured one; the range from low to high includes it.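

In this assay the change of methyl to benzyl reads as a 1.3-fold lower number from compound 1 to compound 3 (0.10 log units; within the scatter), so phenyl in place of hydrogen on a saturated chain carbon bound to a selenium atom gives no shift that can be told from the scatter. Among these compounds, this is the first step between two measured compounds for this change, and it holds for one pair on one shared core, so it supports no general rule about the position. No measurement of any property of these compounds bears on this result.

On these data alone, it remains open whether a longer chain such as butyl, or a chain ending in an amine or a carboxylic acid, would read in the same way in this position on the core of compound 1. As far as these compounds go, it is also open whether methyl to benzyl would read alike on the core of compound 2, with its sulfur, where compound 2 gives > 100000 nM in this assay, which is a limit of the assay and not a number.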